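Series notes: sulfonyl aryl substituent on the shared core

The source may hold more compounds than are shown below. What is called first, only, known or untested is meant among the compounds shown, and "the series" means these compounds.

Compound 3 `CC1CCN(c2c(S(=O)(=O)c3cccc(C#N)c3)cnc3ccc(Cl)cc23)CC1` gives 90% in an assay on isolated protein for displacement of a labelled ligand from metabotropic glutamate receptor 5 (Homo sapiens), with a stated time of 60 min, tested at 1 uM; on this read-out lower numbers stand for less inhibition and higher numbers for more inhibition at the one concentration tested (going by the name of the read-out); it stands second highest of the three numbers, with compound 1 `Cc1ccc(S(=O)(=O)c2cnc3ccc(Cl)cc3c2N2CCC(C)CC2)cc1` giving 95% and compound 2 `CC1CCN(c2c(S(=O)(=O)c3ccccc3)cnc3ccc(F)cc23)CC1` giving 40%. For the measured compounds named here, the one step on the sulfonyl aryl group, a number 5 percentage points lower from compound 1 to compound 3 (within the scatter), lies within the scatter. Compound 4 `CC1CCN(c2c(S(=O)(=O)c3ccccc3)cnc3ccc(Cl)cc23)CC1` differs from compound 3 as hydrogen in place of cyano on an aromatic carbon. Going by the values given here, compound 2 also carries an unsubstituted phenyl on the sulfonyl sulfur but has fluorine where compound 4 has chlorine on the core, so no single-change step relates it to compound 4; its value only shows that a plain phenyl can go together with a low number. On this basis a modest step downward is expected, a number 20 percentage points lower from compound 3 to compound 4 (beyond the scatter), with wide uncertainty. Compound 4 is estimated at 70%, in the range 40% to 95%.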

Compound 4, a percentage reported as inhibition, at one concentration (the size of the read-out at that concentration, not a potency): 59%
Compound 4: middle estimate off by 11 percentage points, on the high side; low and high end bracket the measured number.
By their numbers in this assay, from the lowest: compound 2; then compound 4; then compounds 3 and 1 (each within the scatter of the next).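

Hydrogen in place of cyano gives a number 31 percentage points lower from compound 3 to compound 4 (beyond the scatter), and hydrogen in place of methyl gives a number 36 percentage points lower from compound 1 to compound 4 (beyond the scatter), so in these chloro compounds either substituent on the sulfonyl aryl ring goes with a higher number than plain phenyl. The core halogen carries a step of its own, with chloro in place of fluoro giving a number 19 percentage points higher from compound 2 to compound 4 (beyond the scatter). No supporting data bear on the reason for these steps.

Still open, going by these compounds, is whether the cyano and methyl groups would keep these numbers at each other's ring position. Also open, on these data alone, is how a methoxy group, an amine or a carboxylic acid on this phenyl would compare.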